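The source may hold more compounds than are shown below. What is called first, only, known or untested is meant among the compounds shown, and "the series" means these compounds.

Of the compounds shown here, two sharing one core have been measured so far. In a functional assay on MDA-MB-231 cells (Homo sapiens) for antiproliferative activity, read by MTT assay, with a stated time of 48 h (a higher number here means a weaker inhibitor, a lower number a stronger inhibitor), compound 1 (`C#CCOC(=O)/C(C)=C/CC/C(C)=C/CC/C(C)=C/CC[C@@H]1[C@@]2(C)CCC(=O)C(C)(C)[C@H]2CC[C@@]1(C)O`) gives 114000 nM, and compound 2 (`C/C(=C\CC/C(C)=C/CC[C@@H]1[C@@]2(C)CCC(=O)C(C)(C)[C@H]2CC[C@@]1(C)O)CC/C=C(\C)C(=O)OCc1cn(-c2cccc(Cl)c2)nn1`) gives 103000 nM, so compound 2 stands level with compound 1 within the scatter. Compound 3 (`C/C(=C\CC/C(C)=C/CC[C@@H]1[C@@]2(C)CCC(=O)C(C)(C)[C@H]2CC[C@@]1(C)O)CC/C=C(\C)C(=O)OCc1cn(-c2cccc(F)c2)nn1`) has fluoro in place of chloro on an aromatic carbon, meta to a large group: fluoro in place of chloro on an aromatic carbon. Among the compounds with values here, only one measured step bears on this change, and only indirectly. It is a 1.1-fold lower number from compound 1 to compound 2 (0.04 log units; within the scatter), which came with 1-(3-chlorophenyl)-1H-1,2,3-triazol-4-yl in place of ethynyl and stayed within the scatter. Within the data shown here, no measured step isolates the halogen itself. With that much larger replacement producing no step beyond the scatter, none is expected in this assay for this single-atom exchange. The estimated step is a 1.0-fold higher number from compound 2 to compound 3 (0.01 log units; within the scatter). Compound 3 is expected at about 105000 nM, with an estimated range of 60000 nM to 180000 nM.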

Compound 3, half-maximal inhibitory concentration: 144000 nM
The estimate for compound 3 lay 1.4-fold (0.14 log units) below the measured number; low and high end bracket the measured number.
By their numbers in this assay, from the lowest: compounds 2, 1 and 3 (each within the scatter of the next).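

Exchanging the halogen on the aromatic carbon now has a step of its own in this assay: fluoro in place of chloro gives a 1.4-fold higher number from compound 2 to compound 3 (0.15 log units; within the scatter), so this single-atom exchange does not separate the two compounds. The 1-(3-fluorophenyl)-1H-1,2,3-triazol-4-yl group, set against ethynyl, gives a 1.3-fold higher number from compound 1 to compound 3 (0.10 log units; within the scatter), which shows that a second halogen on this aromatic group also leaves the result level with compound 1. No available evidence explains these readings.

As far as these compounds go, whether an amine or a carboxylic acid in place of the halogen would give a step beyond the scatter remains open. Also open, from the compounds shown here alone, is whether a plain phenyl on the triazole would read level with compound 2 and compound 3.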